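Swapping bromine for fluorine on the triazole-linked benzyl group

The source may report more compounds than this note shows. Statements on the series, on what has been measured and on what is new or still open speak of the compounds shown alone.

Measured so far in a functional assay on HepG2 cells (Homo sapiens) for inhibition, read by MTT assay, with a stated time of 48 h, tested at 10 uM; a lower number here means less inhibition of growth, a higher number more inhibition of growth at the concentration tested:
compound 1 `O=C(/C=C/c1ccc(OCc2cn(Cc3cccc(F)c3)nn2)cc1)c1ccc(Br)cc1` gives 34%;
compound 2 `COc1ccc(C(=O)/C=C/c2ccc(OCc3cn(Cc4ccccc4Br)nn3)cc2)cc1` gives 44%;
compound 3 `COc1ccc(C(=O)/C=C/c2ccc(OCc3cn(Cc4ccc(Br)cc4)nn3)cc2)cc1` gives 59%.

Compound 3 stands highest of the three, a clear distance ahead of compound 2 and further still ahead of compound 1. The change to compound 4 `COc1ccc(C(=O)/C=C/c2ccc(OCc3cn(Cc4cccc(F)c4)nn3)cc2)cc1` is 3-fluorophenyl in place of 4-bromophenyl on a saturated chain carbon bound to an aromatic nitrogen. Within the data shown here, only one measured step touches the same place: a number 15 percentage points higher from compound 2 to compound 3 (beyond the scatter), a modest shift from moving bromine around the ring. Compound 1 carries the same 3-fluorophenyl group as compound 4 but differs elsewhere too, so it offers no clean comparison, only a lower number. Compound 4 is therefore expected to fall, with a number 17 percentage points lower from compound 3 to compound 4 (beyond the scatter), to an estimated 42% in this assay, somewhere between 28% and 58%.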

Compound 4, percent growth inhibition at one concentration: 22%
Estimate against measurement, compound 4: 20 percentage points above, and the stated range ends above it.
By their numbers in this assay, from the lowest: compound 4; then compounds 1 and 2 (each within the scatter of the next); then compound 3.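

In this assay, replacing the bromine-bearing benzyl groups with 3-fluorobenzyl lowers growth inhibition each time, giving a number 37 percentage points lower from compound 3 to compound 4 (beyond the scatter) and a number 22 percentage points lower from compound 2 to compound 4 (beyond the scatter). Methoxy in place of bromo on the other aromatic ring, with the 3-fluorophenyl group held constant, also lowers the number, giving a number 12 percentage points lower from compound 1 to compound 4 (beyond the scatter), which leaves compound 4 lowest of the four. No available measurement accounts for these drops.

Compound 4 changes both the halogen and its ring position, and these compounds cannot separate the two changes. On these data alone, how chlorine or an amine on that benzyl ring would behave remains open.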